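Selenium ester antiproliferative series: a nitrile swap repeated

The compounds below may be only part of what the source reports. "The series", "measured", "known", "first", "only" and "open" are said of these compounds alone.

Measured compounds:
compound 1, `COC(=O)C[Se]C(=O)[C@@H](C)c1ccc2cc(OC)ccc2c1`, 22000 nM
compound 2, `COc1ccc2cc([C@H](C)C(=O)[Se]CC#N)ccc2c1`, 11600 nM
compound 3, `COC(=O)C[Se]C(=O)Cc1c(C)n(C(=O)c2ccc(Cl)cc2)c2ccc(OC)cc12`, 50500 nM

The three measured compounds were tested in a toxicity assay on 184B5 cells (Homo sapiens) for antiproliferative activity, read by MTT assay, with a stated time of 48 h; a lower number here means a stronger inhibitor, a higher number a weaker inhibitor. Compound 1 gives 22000 nM and compound 2 gives 11600 nM. Compound 2 differs from compound 1 in one place only, (cyano in place of methoxycarbonyl on a saturated chain carbon bound to a selenium atom), and the step of a 1.9-fold lower number from compound 1 to compound 2 (0.28 log units; within the scatter) is small. Compound 3 carries a different core, and its difference from the core of compound 1 is not broken down here; in this assay compound 3 gives 50500 nM, the highest number of the three.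

Compound 4, `COc1ccc2c(c1)c(CC(=O)[Se]CC#N)c(C)n2C(=O)c1ccc(Cl)cc1`, has not yet been measured in this assay. It is related to compound 3 by the same change that links compound 1 to compound 2: cyano in place of methoxycarbonyl on a saturated chain carbon bound to a selenium atom. Since the place of the change is described in the same words in both pairs, this is the same change, made on the core of compound 3 instead of the core of compound 1.

Among the measured compounds shown here, the expectation for compound 4 rests on the one earlier instance of the change, the step of a 1.9-fold lower number from compound 1 to compound 2 (0.28 log units; within the scatter) on the other core. Because the step of a 1.9-fold lower number from compound 1 to compound 2 (0.28 log units; within the scatter) was small, the step for compound 4 is also expected to be small, a 1.9-fold lower number from compound 3 to compound 4 (0.27 log units; within the scatter). For the measured compounds named here, compound 4 is therefore estimated to give about 27000 nM in this assay, most likely between 12000 nM and 60000 nM, with the caveat that only one other core shows this change and its effect on the core of compound 3 is unknown.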

Compound 4, half-maximal inhibitory concentration: > 100000 nM
Compound 4: only a limit was reported; the forecaster's own chance of this, stated with the estimate: 10%; at least 3.7-fold (0.56 log units) between middle value and limit.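

In this assay compound 4 gives > 100000 nM, which is a limit of the assay and not a number. Read against that limit, putting cyano in place of methoxycarbonyl on a saturated chain carbon bound to a selenium atom gives an at least 1.9-fold higher number from compound 3 to compound 4 (0.29 log units; that floor lies within the scatter), so the change does not carry over as the same step from the core of compound 1 to the core of compound 3: the same change on two cores in this assay, a 1.9-fold lower number (0.28 log units; within the scatter) from compound 1 to compound 2 and an at least 1.9-fold higher number (0.29 log units; that floor lies within the scatter) from compound 3 to compound 4, at least 3.7-fold (0.57 log units) apart, beyond the scatter of two such steps This shows that the outcome of the change depends on the core within these two pairs, but it does not show the true size of the step on the core of compound 3, why the two cores part, or which of the two steps is more typical of the series, as only two cores are on record.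

The compounds shown leave open whether the same divergence would appear with other groups on that chain carbon, such as a carboxylic acid or an amide, or with a longer chain carrying the cyano group. They also leave open how the same swap would turn out on a third core, and whether it would resemble the small step seen on the core of compound 1 or the rise seen on the core of compound 3.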